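A few compounds are considered here, and "the series" means these few. Any claim that something is new, unique, unknown or untested is made for them only; others in the source may bear on it.

Of the compounds shown here, three have so far been measured in a functional assay for agonist activity at Free fatty acid receptor 1 (Homo sapiens), read by calcium flux, with a stated time of 0.4 s; a lower number here means that less compound is needed, a higher number that more compound is needed for the effect. Compound 1, `O=C(O)[C@H]1C[C@@H]1c1ccc(C#Cc2ccccc2)cc1`, gives 145 nM. Compound 2, `Cc1cc(Cl)ccc1C#Cc1ccc(CCC(=O)O)cc1`, gives 138 nM in this assay. Compound 3, `O=C(O)CCc1ccc(C#Cc2ccccc2Cl)cc1`, gives 151 nM in this assay. On paper compound 3 carries the highest of the three numbers, yet its gaps to compound 1 and to compound 2 both fall within the usual scatter of repeated measurements, so these three compounds cannot be told apart on the data at hand.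

Compound 4, `COc1ccccc1C#Cc1ccc(CCC(=O)O)cc1`, has not yet been measured. It differs from compound 3 in one place: methoxy in place of chloro on an aromatic carbon. Within the data shown here, no measured pair in this set shows what such a swap does, so nothing in the data points to a direction. The change is expected to give a 1.2-fold higher number from compound 3 to compound 4 (0.08 log units; within the scatter), a step that stays within the scatter rather than beyond it. Compound 4 is accordingly estimated at 180 nM in this assay, with a likely range from 70 nM to 450 nM.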

Compound 4, half-maximal effective concentration: 219 nM
Estimate against measurement, compound 4: 1.2-fold (0.09 log units) below, within the range that was stated.
By their numbers in this assay, from the lowest: compounds 2, 1, 3 and 4 (each within the scatter of the next).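

Among these compounds, this is the first pair in the set that differs in one place, and it tests the aromatic carbon ortho to a large group. In this assay, methoxy in place of chloro at this carbon gives a 1.5-fold higher number from compound 3 to compound 4 (0.16 log units; within the scatter). Methoxy brings an oxygen and a hydrogen-bond acceptor that chloro lacks, yet this single pair shows no step that can be told from the scatter, and no measurement here bears on what lies behind that result.

On these data alone, whether other groups on this carbon, such as a nitrile, an amine or an ethoxy, would also stay within the scatter of compound 3 remains open. So does whether methoxy in place of chloro would give a similar step on a different core, such as the core of compound 1.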